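This account rests on a few compounds, and the source may have more. Where it says the series, first, only, none or still open, it means among the compounds named here.

Working notes on the series: two compounds have been read so far in an ADME assay on MDCK cells (Canis lupus familiaris) for permeability, in the apical to basolateral direction; on this read-out lower numbers stand for lower permeability and higher numbers for higher permeability. Compound 1 (`CC(C)[C@@H](c1ccc(-c2ccc3cccc(F)c3c2)[nH]c1=O)[C@@H]1OC(=O)NC1=O`) gives 3.15 10^-6 cm/s, the lower of the two numbers. Compound 2 (`CC(C)C(CC1NC(=O)NC1=O)c1ccc(-c2ccc3cccc(F)c3c2)[nH]c1=O`) gives 17.1 10^-6 cm/s, higher than compound 1 by more than the scatter. Among the compounds with values here, these two do not differ in one place only, so the series offers no clean measured step.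

Compound 3 (`CC(C)[C@H](C[C@@H]1OC(=O)NC1=O)c1ccc(-c2ccc3cccc(F)c3c2)[nH]c1=O`) is next. It carries (2,4-dioxo-1,3-oxazolidin-5-yl)methyl in place of the 2,4-dioxo-1,3-oxazolidin-5-yl of compound 1, on a saturated chain carbon bound to an aromatic carbon and a saturated chain carbon: (2,4-dioxo-1,3-oxazolidin-5-yl)methyl in place of 2,4-dioxo-1,3-oxazolidin-5-yl on a saturated chain carbon bound to an aromatic carbon and a saturated chain carbon.

Within the data shown here, with no measured precedent for this change, the expectation in this assay is a small rise, probably not clearly beyond the scatter. Among the measured compounds shown here, the only guide to its direction is the higher number of compound 2 at 17.1 10^-6 cm/s, and that is a weak one. The expected change is a 1.9-fold higher number from compound 1 to compound 3 (0.28 log units; within the scatter). For compound 3 the estimated value is 6 10^-6 cm/s, with an expected range of 2.5 10^-6 cm/s to 14 10^-6 cm/s.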

Compound 3, apparent permeability: 10.8 10^-6 cm/s
Compound 3: the middle estimate sits 1.8-fold (0.26 log units) below what was measured; low and high end bracket the measured number.
By their numbers in this assay, from the lowest: compound 1; then compounds 3 and 2 (each within the scatter of the next).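

The series now has its first clean measured step: in this assay, (2,4-dioxo-1,3-oxazolidin-5-yl)methyl in place of 2,4-dioxo-1,3-oxazolidin-5-yl on a saturated chain carbon bound to an aromatic carbon and a saturated chain carbon gives a 3.4-fold higher number from compound 1 to compound 3 (0.54 log units; beyond the scatter), a modest change but one beyond the scatter. The read-out at this position therefore responds to a single added carbon, even though the five-membered ring stays the same and the counts of hydrogen-bond donors and acceptors, double bonds outside aromatic rings and net charge are unchanged in the swap. The data at hand hold no measurement that bears on why the number moves.

From the compounds shown here alone, one step gives a single point, so it remains open whether a longer chain, such as 2-(2,4-dioxo-1,3-oxazolidin-5-yl)ethyl, would continue the same trend or reverse it. Going by these compounds, it is equally open whether the step holds when the ring is replaced by a carboxylic acid or an amine on the same chain, and how much of it depends on the ring itself rather than on the added carbon.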